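Trifluoromethyl on the Terminal Phenyl of a Diaryl Urea

This account rests on a few compounds, and the source may have more. Where it says the series, first, only, none or still open, it means among the compounds named here.

Compound 1 `O=C(Nc1ccccc1)Nc1cccc(CNc2nccnc2Cl)c1` is tested in a functional assay on MGC-803 cells (Homo sapiens) for antiproliferative activity, read by MTT assay, with a stated time of 48 h (a lower number here means a stronger inhibitor, a higher number a weaker inhibitor), where compound 1 gives 16300 nM, the highest of the three numbers shown. Compound 2 `O=C(Nc1cccc(CNc2nccnc2Cl)c1)Nc1ccccc1F` gives 6440 nM, and compound 3 `Cc1ccccc1NC(=O)Nc1cccc(CNc2nccnc2Cl)c1` gives 14000 nM. The step of a 2.5-fold lower number from compound 1 to compound 2 (0.40 log units; beyond the scatter) lies beyond the scatter, whereas a 1.2-fold lower number from compound 1 to compound 3 (0.07 log units; within the scatter) does not; between the two substituted compounds stands a 2.2-fold higher number from compound 2 to compound 3 (0.34 log units; beyond the scatter). Compound 4 `O=C(Nc1ccc(C(F)(F)F)cc1)Nc1cccc(CNc2nccnc2Cl)c1` differs from compound 1 by trifluoromethyl in place of hydrogen on an aromatic carbon, on an aromatic carbon of a six-membered aromatic ring of carbon only. Both measured substitutions on that ring of the core of compound 1 lowered the number at most modestly, so a modest lowering is expected here, a 2.0-fold lower number from compound 1 to compound 4 (0.31 log units; beyond the scatter). Compound 4 is therefore estimated at 8000 nM, within a range of 3000 nM to 20000 nM.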

Compound 4, half-maximal inhibitory concentration: 6910 nM
For compound 4 the middle estimate is 1.2-fold (0.06 log units) above the measured one; low and high end bracket the measured number.
By their numbers in this assay, from the lowest: compounds 2 and 4 (each within the scatter of the next); then compounds 3 and 1 (each within the scatter of the next).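

The step of a 2.4-fold lower number from compound 1 to compound 4 (0.37 log units; beyond the scatter) shows that in this assay the number can also fall beyond the scatter with a substituent para to a large group. It also shows that trifluoromethyl, with its 4 heavy atoms, is accepted at this position on the ring. Nothing given here explains the step. Going by these compounds, whether an amine or a carboxylic acid on this same carbon would lower the number remains open. Also open, on these data alone, is whether trifluoromethyl would give a similar step on the other carbons of the ring.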